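Replacing the sulfonamide of compound 3 with a sulfo group

The compounds below may be only part of what the source reports. "The series", "measured", "known", "first", "only" and "open" are said of these compounds alone.

Compounds measured so far in an assay for binding affinity to adenosine receptor A1 (Bos taurus); on this read-out lower numbers stand for stronger inhibition and higher numbers for weaker inhibition:
- compound 1, `CCn1c(=O)c2nc(-c3ccc(S(=O)(=O)N4CCOCC4)cc3)[nH]c2n(CC)c1=O`: 13 nM
- compound 2, `CCn1c(=O)c2nc(-c3ccc(S(=O)(=O)NCCCN(C)C)cc3)[nH]c2n(CC)c1=O`: 1.6 nM
- compound 3, `CCn1c(=O)c2nc(-c3ccc(S(=O)(=O)NCCN(C)C)cc3)[nH]c2n(CC)c1=O`: 3.3 nM

Within this small set, compound 3 sits in the middle: a 2.1-fold higher number from compound 2 to compound 3 (0.31 log units; beyond the scatter) places it behind compound 2, while a 3.9-fold lower number from compound 1 to compound 3 (0.60 log units; beyond the scatter) puts it ahead of compound 1. The new compound 4, `CCn1c(=O)c2nc(-c3ccc(S(=O)(=O)O)cc3)[nH]c2n(CC)c1=O`, arises from compound 3 by one change on the sulfonyl sulfur: hydroxy in place of (2-(dimethylamino)ethyl)amino on a sulfonyl sulfur.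

The measured steps touch only the group on the sulfonyl sulfur, and all of them swap one nitrogen-bearing substituent for another: an 8.1-fold lower number from compound 1 to compound 2 (0.91 log units; beyond the scatter) and a 3.9-fold lower number from compound 1 to compound 3 (0.60 log units; beyond the scatter) are modest, and a 2.1-fold higher number from compound 2 to compound 3 (0.31 log units; beyond the scatter) is smaller still. None of them removes the sulfonamide nitrogen and its attached chain altogether, which is what happens here. The change is therefore larger in kind than anything measured, and the direction is uncertain. Since the two steps that added a dimethylamino chain both lowered the number, taking the whole chain away is expected to move the number upward, possibly beyond a modest amount; compound 4 is estimated at 100 nM, within 15 nM to 800 nM, corresponding to an expected step of a 30-fold higher number from compound 3 to compound 4 (1.48 log units; beyond the scatter).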

Compound 4, half-maximal inhibitory concentration in the adenosine receptor A1 assay: 755 nM
Beside the measured number, compound 4's estimate is 7.6-fold (0.88 log units) below it; measured number inside the range.
By their numbers in the adenosine receptor A1 assay, from the lowest: compound 2; then compound 3; then compound 1; then compound 4.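

Hydroxy on the sulfonyl sulfur gives a far larger shift than any swap among the nitrogen-bearing groups, and all three steps in the adenosine receptor A1 assay point the same way: a 230-fold higher number from compound 3 to compound 4 (2.36 log units; beyond the scatter), a 470-fold higher number from compound 2 to compound 4 (2.67 log units; beyond the scatter) and a 58-fold higher number from compound 1 to compound 4 (1.76 log units; beyond the scatter). In a physicochemical assay for solubility, in phosphate buffer, at pH 7.4 (on this read-out higher numbers stand for higher solubility and lower numbers for lower solubility), the same change moves the number in the favourable direction, with an at least 510-fold higher number from compound 3 to compound 4 (2.71 log units; beyond the scatter). In the physicochemical assay compound 3 gives 110 ug/mL. In the physicochemical assay compound 4 gives > 57000 ug/mL, which is a limit of the assay and not a number: the limit of > 57000 ug/mL in the physicochemical assay, at which 1 of the 2 values shown sits.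

The compounds shown leave open whether the loss in binding comes from removing the nitrogen-bearing group or from the sulfo group itself, which an unsubstituted sulfonamide or a carboxylic acid on the same ring could help separate. They also leave open whether a chain ending in a carboxylic acid would keep both read-outs favourable.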